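The compounds below may be only part of what the source reports. "The series", "measured", "known", "first", "only" and "open" are said of these compounds alone.

Solubility series, read in a physicochemical assay for solubility, read by HPLC, using the shake flask method, in phosphate buffer, with a stated time of 2 h, at pH 6.5; on this read-out higher numbers stand for higher solubility and lower numbers for lower solubility:
compound 1 `Nc1ncc(-c2ccc(C(=O)O)cc2)nc1-c1ccc(C(F)(F)F)cc1`: 95000 nM
compound 2 `Nc1ncc(-c2ccc(C(=O)N3CC[C@H](O)C3)cc2)nc1-c1ccc(C(F)(F)F)cc1`: 68000 nM
compound 3 `Nc1ncc(-c2ccc(C(=O)N3CCC(O)C3)cc2)nc1-c1ccc(C(F)(F)F)cc1`: 77000 nM

Compound 3 stands second highest of the three numbers in this assay; its gaps to the others, a 1.1-fold higher number from compound 2 to compound 3 (0.05 log units; within the scatter) and a 1.2-fold lower number from compound 1 to compound 3 (0.09 log units; within the scatter), both sit within the scatter, so no order among the three is established. Compound 4 `Nc1ncc(-c2ccc(C(=O)N3CCC(N)CC3)cc2)nc1-c1ccc(C(F)(F)F)cc1` differs from compound 3 by 4-aminopiperidin-1-yl in place of 3-hydroxypyrrolidin-1-yl on a carbonyl carbon. For the measured compounds named here, no measured step covers this exchange: the steps of a 1.4-fold lower number from compound 1 to compound 2 (0.15 log units; within the scatter) and a 1.2-fold lower number from compound 1 to compound 3 (0.09 log units; within the scatter) concern only the amide in place of the acid, and compound 2 and compound 3 differ only in drawn configuration (the fact that one of compounds 2 and 3 is drawn with a defined configuration and the other without, at the place where they differ). All measured steps lie within the scatter, so for compound 4 the expected step is a 1.4-fold higher number from compound 3 to compound 4 (0.15 log units; within the scatter), not confidently beyond the scatter. Compound 4 is therefore estimated at 110000 nM in this assay, with a range from 50000 nM to 250000 nM.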

Compound 4, solubility: 88000 nM
Compound 4: middle estimate off by 1.3-fold (0.10 log units), on the high side; the measured number falls inside the stated range.
By their numbers in this assay, from the lowest: compounds 2, 3, 4 and 1 (each within the scatter of the next).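

In this assay, the exchange of 3-hydroxypyrrolidin-1-yl for 4-aminopiperidin-1-yl on a carbonyl carbon gives a 1.1-fold higher number from compound 3 to compound 4 (0.06 log units; within the scatter) and a 1.3-fold higher number from compound 2 to compound 4 (0.11 log units; within the scatter), so a six-membered ring carrying an amino group reads level with the five-membered ring carrying a hydroxy group. Against the acid, the same group gives a 1.1-fold lower number from compound 1 to compound 4 (0.03 log units; within the scatter), which extends the flat picture to a third amide. Nothing measured here bears on the reason for these steps.

Open, going by these compounds, is whether any group on this carbonyl carbon leaves the scatter, for example a morpholine ring, a dimethylamino group or a longer chain ending in an amine.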